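Notes on the shared core: trifluoromethyl removed from compound 2

The source may hold more compounds than are shown below. What is called first, only, known or untested is meant among the compounds shown, and "the series" means these compounds.

Measured so far:
compound 1, `O=C(O)COc1ccc(Cl)cc1C#Cc1ccc(CO)cc1F`: 28 nM
compound 2, `O=C(O)COc1ccc(Cl)cc1C#Cc1cccc(C(F)(F)F)c1`: 92 nM

Both values come from an assay on CHO cells for displacement of a labelled ligand from prostaglandin D2 receptor 2 (Homo sapiens), read by scintillation counting; on this read-out higher numbers stand for weaker inhibition and lower numbers for stronger inhibition. Of the two numbers, compound 2 stands highest in this assay; compound 1 sits at a lower number, and the gap between them is beyond the usual scatter of repeated measurements. Compound 3, `O=C(O)COc1ccc(Cl)cc1C#Cc1ccccc1`, has not yet been measured in this assay. It differs from compound 2 in one place: hydrogen in place of trifluoromethyl on an aromatic carbon. For the measured compounds named here, no measured pair shows this change, so its size cannot be read from the data and nothing in the two measured compounds fixes its direction. The expectation is a modest step toward a higher number, a 1.7-fold higher number from compound 2 to compound 3 (0.24 log units; within the scatter), roughly at the edge of the scatter. Compound 3 is therefore expected to give 160 nM in this assay, within a range from 50 nM to 500 nM.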

Compound 3, inhibition constant: 108 nM
For compound 3 the middle estimate is 1.5-fold (0.17 log units) above the measured one; low and high end bracket the measured number.
By their numbers in this assay, from the lowest: compound 1; then compounds 2 and 3 (each within the scatter of the next).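

In this assay, for the compounds shown here, hydrogen in place of trifluoromethyl on this aromatic carbon gives a 1.2-fold higher number from compound 2 to compound 3 (0.07 log units; within the scatter), the first direct reading of this change. At this position, meta to a large group, losing the four heavy atoms of trifluoromethyl therefore leaves the number indistinguishable from that of the parent, so this group is not needed to hold the value in this assay. Nothing measured here accounts for this result.

Only trifluoromethyl and hydrogen are shown on this aromatic carbon, so whether an amine, a carboxylic acid or a longer chain there would move the number stays open. Going by these compounds alone, also open is whether the same swap reads alike on other substituted versions of the shared core, as only this one pair carries it.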